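The source may report more compounds than this note shows. Statements on the series, on what has been measured and on what is new or still open speak of the compounds shown alone.

Measured compounds in an ADME assay on microsomes from liver (Mus musculus) for metabolic stability, read by LC-MS, with a stated time of 30 min, tested at 0.1 uM; a lower number here means that less of the compound is left, a higher number that more of the compound is left:
compound 1, `FC(F)(F)c1cccc(-c2nc3cnc(Nc4ccccn4)cc3[nH]2)c1`: 47%
compound 2, `FC(F)(F)c1cccc(-c2nc3cnc(Nc4ccncn4)cc3[nH]2)c1`: 89%

Compound 2 stands highest of the two numbers in this assay; its nearest neighbour is compound 1, and the step of a number 42 percentage points higher from compound 1 to compound 2 (beyond the scatter) lies beyond the scatter. Compound 3, `N#Cc1ccc(Nc2cc3[nH]c(-c4cccc(C(F)(F)F)c4)nc3cn2)nc1`, has not yet been measured. It differs from compound 2 in one place: 5-cyanopyridin-2-yl in place of pyrimidin-4-yl on a nitrogen on an aromatic ring. Among the compounds with values here, only one measured step bears on this change, namely a number 42 percentage points higher from compound 1 to compound 2 (beyond the scatter), and that step ran in the opposite sense, from a pyridin-2-yl to a pyrimidin-4-yl. Within the data shown here, compound 3 returns to a pyridin-2-yl ring, now carrying a nitrile, for which no measured pair gives guidance. The expected step is therefore a decrease, a number 24 percentage points lower from compound 2 to compound 3 (beyond the scatter), of moderate size but with wide uncertainty. Compound 3 is expected to give about 65% in this assay, within a range from 40% to 88%.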

Compound 3, percent of the compound remaining: 47%
Estimate against measurement, compound 3: 18 percentage points above; measured number inside the range.
By their numbers in this assay, from the lowest: compounds 1 and 3 (each within the scatter of the next); then compound 2.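

In this assay the change to the cyano-bearing ring gives a number that drops back, a number 42 percentage points lower from compound 2 to compound 3 (beyond the scatter) and a large step, so the 5-cyanopyridin-2-yl group does not hold what the pyrimidin-4-yl group showed on this nitrogen. The earlier pair could not separate the ring itself from what a substituent on it might do, and here the cyano in place of hydrogen on an aromatic carbon gives no change at the digits printed from compound 1 to compound 3 (within the scatter) in this read-out. Across these three compounds the number therefore goes with the ring, with the pyrimidin-4-yl compound alone standing apart, but nothing at hand gives a measured reason for either step.

From the compounds shown here alone, whether a methoxy or a primary amide in place of the cyano on the pyridin-2-yl ring would behave as the cyano does stays open. So does whether a cyano on the pyrimidin-4-yl ring would keep the higher number.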